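Three Changed Stereocentres at the Assay Limit

The compounds below may be only part of what the source reports. "The series", "measured", "known", "first", "only" and "open" are said of these compounds alone.

Compound 1 `C=C(C)[C@H]1CC[C@@](C)(O)[C@@H]1/C=C/C(C)=C/[C@H]1C[C@@]23[C@H](OCCC[C@@H]2/C(=C(\C)C=O)CC[C@]3(C)O)O1` and compound 2 `C=C(C)[C@H]1CC[C@@](C)(O)[C@@H]1/C=C/C(C)=C/[C@H]1C[C@@]23[C@H](OCCC[C@@H]2/C(=C(/C)C=O)CC[C@]3(C)O)O1` were both tested in a functional assay on BV-2 cells (Mus musculus) for inhibition, read by Griess assay, with a stated time of 24 h; on this read-out lower numbers stand for stronger inhibition and higher numbers for weaker inhibition. Compound 1 gives > 10000 nM, which is a limit of the assay and not a number. Compound 2 gives > 10000 nM, which is also only a limit. Going by the values given here, the one measured step between them, a switch of a double bond from E to Z, is a step that the two limits leave unreadable from compound 1 to compound 2, so it offers no size to build on.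

Compound 3 `C=C(C)[C@@H]1CC[C@](C)(O)[C@H]1/C=C/C(C)=C/[C@H]1C[C@@]23[C@H](OCCC[C@@H]2/C(=C(/C)C=O)CC[C@]3(C)O)O1` keeps the atoms and bonds of compound 2, and the change is this: the two compounds have the same atoms and bonds and differ only in configuration as drawn: 3 of 11 stereo elements differ; a stereocentre at a saturated ring carbon is drawn S in compound 2 and R in compound 3; a stereocentre at a saturated ring carbon is drawn R in compound 2 and S in compound 3; a stereocentre at a saturated ring carbon is drawn R in compound 2 and S in compound 3. Among the compounds with values here, compound 2 gives no number to start from, and no measured step tests these stereocentres, so no firm direction can be expected. The estimated step is a step that the limit leaves unreadable from compound 2 to compound 3. In this assay, compound 3 is expected near 12000 nM, with an estimated range from 3000 nM to 40000 nM, and quite possibly only a limit again.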

Compound 3, half-maximal inhibitory concentration: > 10000 nM
Compound 3: no number, only a limit; the forecaster's own chance of this, stated with the estimate: 65%; the middle value lies beyond the limit too.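

No step between compound 1, compound 2 and compound 3 can be read, as all three values are limits and not numbers: the limit of > 10000 nM in this assay, at which 3 of the 3 values shown sit.

Going by these compounds, whether the switch of the double bond or the three changed stereocentres affect inhibition in this assay remains open.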